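Aryl replacement on the shared core: clearance notes

This account rests on a few compounds, and the source may have more. Where it says the series, first, only, none or still open, it means among the compounds named here.

Measured so far:
- compound 1 `CC(C)(C)n1cc(-c2cc(C(O)(C(F)(F)F)C(F)(F)F)cnc2N2CCN(S(=O)(=O)c3ccc(N)nc3)CC2)cn1`: 459 mL.min-1.g-1
- compound 2 `Cc1ccc(-c2cc(C(O)(C(F)(F)F)C(F)(F)F)cnc2N2CCN(S(=O)(=O)c3ccc(N)nc3)CC2)cn1`: 182 mL.min-1.g-1

Both compounds were run in an ADME assay (liver) for metabolic stability, with Liver microsome (Rattus norvegicus) as the target, using microsomes and NADPH, with a stated time of 30 min, tested at 1 uM; a higher number here means faster removal of the compound, a lower number slower removal. Compound 1 gives 459 mL.min-1.g-1 and compound 2 gives 182 mL.min-1.g-1. Going by the values given here, compound 2 therefore stands at the lower of the two numbers, with compound 1 as its only neighbour; the only step recorded, a 2.5-fold lower number from compound 1 to compound 2 (0.40 log units; beyond the scatter), concerns exactly this position on the shared core and shows that exchanging the aryl group there can move the read-out by a modest but real amount.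

Compound 3 `Nc1ccc(S(=O)(=O)N2CCN(c3ncc(C(O)(C(F)(F)F)C(F)(F)F)cc3-c3cc4ccccc4s3)CC2)cn1` is not yet measured. It differs from compound 2 as follows: 1-benzothiophen-2-yl in place of 6-methylpyridin-3-yl on an aromatic carbon. Among the compounds with values here, no measured pair covers this particular exchange, so the step from compound 1 to compound 2 is the only guide to its likely size, and it gives no direction for the new group. A step of similar magnitude is expected, a 1.8-fold higher number from compound 2 to compound 3 (0.26 log units; within the scatter), with the direction left open and a wide range kept. Compound 3 is estimated at 330 mL.min-1.g-1, between 130 mL.min-1.g-1 and 850 mL.min-1.g-1.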

Compound 3, intrinsic clearance in microsomes: 315 mL.min-1.g-1
Beside the measured number, compound 3's estimate is 1.0-fold (0.02 log units) above it; the range from low to high includes it.
By their numbers in this assay, from the lowest: compounds 2, 3 and 1 (each within the scatter of the next, the first and the last beyond it).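

In this assay, 1-benzothiophen-2-yl cannot be separated from either earlier group at this position: the result is a 1.7-fold higher number from compound 2 to compound 3 (0.24 log units; within the scatter) against 6-methylpyridin-3-yl and a 1.5-fold lower number from compound 1 to compound 3 (0.16 log units; within the scatter) against 1-(tert-butyl)-1H-pyrazol-4-yl. Going by these compounds alone, the earlier pair showed only that two groups on this aromatic carbon could be told apart, at a 2.5-fold lower number from compound 1 to compound 2 (0.40 log units; beyond the scatter); the third group, which brings a five-membered aromatic ring with a six-membered aromatic ring of carbon only, fits within the scatter of both, so these three groups give a graded set with only its two ends clearly apart, not a ranking of ring types. Nothing measured here accounts for any of these steps.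

The compounds shown leave open whether a group of another kind on this aromatic carbon, such as a morpholine, a primary amine or a carboxylic acid, would take the read-out outside the span set by compound 2 and compound 1. They also leave open whether a simple phenyl or a methyl-substituted thiophene would stay within that span, and so which part of the larger groups, if any, matters for clearance.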